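A few compounds are considered here, and "the series" means these few. Any claim that something is new, unique, unknown or untested is made for them only; others in the source may bear on it.

Working notes on the series. The shared core carries a propyl chain on a six-membered aromatic ring with one nitrogen, and the ring position under study is varied. Compound 1 `CCCc1cccc(=O)n1Cc1ccc(-c2ccccc2-c2nn[nH]n2)cc1` bears hydrogen there; in a functional assay on the whole organism with Rattus norvegicus as the target (on this read-out lower numbers stand for an effect already at smaller amounts and higher numbers for an effect only at larger amounts of compound), compound 1 gives 1.1 mg/kg. Compound 2 `CCCc1cc(O)cc(=O)n1Cc1ccc(-c2ccccc2-c2nn[nH]n2)cc1` bears hydroxy, and compound 2 gives 0.048 mg/kg. Compound 3 `CCCc1cc(SC)cc(=O)n1Cc1ccc(-c2ccccc2-c2nn[nH]n2)cc1` bears methylsulfanyl, and compound 3 gives 0.28 mg/kg. Compound 3 thus stands second highest of the three numbers, with a 3.9-fold lower number from compound 1 to compound 3 (0.59 log units; beyond the scatter) and a 5.8-fold higher number from compound 2 to compound 3 (0.77 log units; beyond the scatter) setting it apart from both neighbours. Compound 4 `CCCc1cc(C(=O)O)cc(=O)n1Cc1ccc(-c2ccccc2-c2nn[nH]n2)cc1` is not yet measured; the change is carboxy in place of methylsulfanyl on an aromatic carbon.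

Within the data shown here, both substituents placed at this position so far lowered the number relative to hydrogen: a 23-fold lower number from compound 1 to compound 2 (1.36 log units; beyond the scatter) and a 3.9-fold lower number from compound 1 to compound 3 (0.59 log units; beyond the scatter). The carboxy group enters with a hydrogen-bond donor and acceptor, as the hydroxy of compound 2 did, so the expected step is a 1.9-fold lower number from compound 3 to compound 4 (0.27 log units; within the scatter), a lowering rather than a rise. Compound 4 is estimated at 0.15 mg/kg, with a range from 0.03 mg/kg to 0.8 mg/kg.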

Compound 4, dose for 50% inhibition: 0.078 mg/kg
Compound 4: the middle estimate sits 1.9-fold (0.28 log units) above what was measured, within the range that was stated.
By their numbers in this assay, from the lowest: compounds 2 and 4 (each within the scatter of the next); then compound 3; then compound 1.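

In this assay carboxy is a third substituent at this position, opposite the ring nitrogen, that lowers the number relative to hydrogen, with a 14-fold lower number from compound 1 to compound 4 (1.15 log units; beyond the scatter) as its step, so none of the three groups shown goes against this direction. Replacing methylsulfanyl with carboxy gives a 3.6-fold lower number from compound 3 to compound 4 (0.56 log units; beyond the scatter) and brings the number level with that of the hydroxy compound, as a 1.6-fold higher number from compound 2 to compound 4 (0.21 log units; within the scatter) shows, so the two groups with a hydrogen-bond donor cannot be separated and both stand apart from methylsulfanyl, which has none. Nothing available explains this grouping.

As far as these compounds go, it remains open whether a methyl ester or an amine at this position would fall with the hydroxy and carboxy groups or with methylsulfanyl. The compounds shown also leave open whether the same order would hold with a longer chain in place of propyl.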